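This account rests on a few compounds, and the source may have more. Where it says the series, first, only, none or still open, it means among the compounds named here.

Series notes. The shared core is held constant and the group at the end of the chain on the amide-type nitrogen is varied. Compound 1 `CC(C)(C)c1ccc(C(=O)N2CCC3(CC2)C(=O)N(CC(=O)NCCN)CN3c2ccccc2)cc1` carries a free amine at that end; in an assay on HEK293 cells for displacement of a labelled ligand from NPC1-like intracellular cholesterol transporter 1 (Homo sapiens) (on this read-out lower numbers stand for stronger inhibition and higher numbers for weaker inhibition), compound 1 gives 7000 nM. Compound 2 `CC(C)(C)OC(=O)NCCNC(=O)CN1CN(c2ccccc2)C2(CCN(C(=O)c3ccc(C(C)(C)C)cc3)CC2)C1=O` has tert-butoxycarbonyl in place of hydrogen on the amine nitrogen; in this assay compound 2 gives 10900 nM. The step is a 1.6-fold higher number from compound 1 to compound 2 (0.19 log units; within the scatter). Compound 3 `CC(C)(C)c1ccc(C(=O)N2CCC3(CC2)C(=O)N(CC(=O)NCCC(=O)O)CN3c2ccccc2)cc1` has carboxy in place of amino on the saturated chain carbon; in this assay compound 3 gives 11400 nM. Compound 3 stands at one end of the measured numbers, but both a 1.6-fold higher number from compound 1 to compound 3 (0.21 log units; within the scatter) and a 1.0-fold higher number from compound 2 to compound 3 (0.02 log units; within the scatter) fall within the scatter, so the three compounds cannot be separated.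

Compound 4 `CC(C)(C)c1ccc(C(=O)N2CCC3(CC2)C(=O)N(CC(=O)N2CCN(S(C)(=O)=O)CC2)CN3c2ccccc2)cc1` is not yet measured. It differs from compound 3 by 4-(methylsulfonyl)piperazin-1-yl in place of (2-carboxyethyl)amino on a carbonyl carbon. The three measured steps at this end of the molecule, a 1.6-fold higher number from compound 1 to compound 2 (0.19 log units; within the scatter), a 1.6-fold higher number from compound 1 to compound 3 (0.21 log units; within the scatter) and a 1.0-fold higher number from compound 2 to compound 3 (0.02 log units; within the scatter), all stay within the scatter, though none of them replaces the amide-type nitrogen with a ring. On that basis compound 4 is expected to behave like its neighbours, with a 1.1-fold lower number from compound 3 to compound 4 (0.06 log units; within the scatter) expected to lie within the scatter. The estimate for compound 4 in this assay is 10000 nM, with a range from 4000 nM to 25000 nM.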

Compound 4, half-maximal inhibitory concentration: 19000 nM
Estimate against measurement, compound 4: 1.9-fold (0.28 log units) below; the measured number falls inside the stated range.
By their numbers in this assay, from the lowest: compounds 1, 2, 3 and 4 (each within the scatter of the next, the first and the last beyond it).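

With 4-(methylsulfonyl)piperazin-1-yl on the carbonyl carbon, the series gains its first step beyond the scatter in this assay, a modest one: a 2.7-fold higher number from compound 1 to compound 4 (0.43 log units; beyond the scatter). The same group cannot be separated from the two other chains, since a 1.7-fold higher number from compound 3 to compound 4 (0.22 log units; within the scatter) and a 1.7-fold higher number from compound 2 to compound 4 (0.24 log units; within the scatter) both stay within the scatter, so the separation holds only against the (2-aminoethyl)amino group of compound 1, and compound 4 also shows that a six-membered non-aromatic ring with 0 hydrogen-bond donors can sit at this carbon without a step beyond the scatter from compound 3 or compound 2. Nothing available bears on why the number from compound 4 separates from that of compound 1 alone.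

The compounds shown do not tell whether the ring or the methylsulfonyl group carries the step from compound 1, which a piperazine with a free ring amine or a morpholine on the same carbonyl carbon would help to separate. Also open, from the compounds shown here alone, is whether any group at this carbon can lower the number beyond the scatter, for instance a longer chain ending in an amine.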